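This account rests on a few compounds, and the source may have more. Where it says the series, first, only, none or still open, it means among the compounds named here.

Measured in a functional assay on SK-OV-3 cells (Homo sapiens) for cytotoxicity, read by MTT assay, with a stated time of 3 days (a lower number here means a stronger inhibitor, a higher number a weaker inhibitor), so far:
Compound 1 `CCNc1nc(SCc2nc3ccccc3[nH]2)nc(-c2ccccc2)c1C#N` gives 7.35 nM
Compound 2 `N#Cc1c(Nc2nccs2)nc(SCc2nc3ccccc3[nH]2)nc1-c1ccccc1` gives 5.81 nM
Compound 3 `N#Cc1c(NC(N)=S)nc(SCc2nc3ccccc3[nH]2)nc1-c1ccccc1` gives 7.81 nM

Compound 3 lies within the scatter of both other compounds, so these numbers do not set it apart. Compound 4 `CN1CCN(c2nc(SCc3nc4ccccc4[nH]3)nc(-c3ccccc3)c2C#N)CC1`, not yet measured, differs from compound 3 on an aromatic carbon (a group of 7 heavy atoms (5 carbon, 2 nitrogen; one six-membered non-aromatic ring with 2 hetero atoms) in place of a group of 4 heavy atoms (1 carbon, 2 nitrogen, 1 sulfur; no ring), on an aromatic carbon). Among the compounds with values here, three measured steps bear on this change (a 1.3-fold lower number from compound 1 to compound 2 (0.10 log units; within the scatter)) and (a 1.1-fold higher number from compound 1 to compound 3 (0.03 log units; within the scatter)) and (a 1.3-fold higher number from compound 2 to compound 3 (0.13 log units; within the scatter)). All stayed within the scatter, but each swaps a group on a nitrogen on an aromatic ring and none brings in a six-membered non-aromatic ring, so they guide only loosely. No step beyond the scatter is expected in this assay in either direction. The estimate means an expected step (a 1.0-fold higher number from compound 3 to compound 4 (0.01 log units; within the scatter)). Compound 4 is expected at 8 nM within a range from 3 nM to 25 nM in this measurement.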

Compound 4, half-maximal inhibitory concentration: 1600 nM
For compound 4 the middle estimate is 200-fold (2.30 log units) below the measured one; measured number outside the range, above it.
By their numbers in this assay, from the lowest: compounds 2, 1 and 3 (each within the scatter of the next); then compound 4.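

Putting 4-methylpiperazin-1-yl on this aromatic carbon in this assay gives a 200-fold higher number from compound 3 to compound 4 (2.31 log units; beyond the scatter) and a 280-fold higher number from compound 2 to compound 4 (2.44 log units; beyond the scatter) and also a 220-fold higher number from compound 1 to compound 4 (2.34 log units; beyond the scatter) in one change, whereas swaps on the attached nitrogen had stayed within the scatter. The position is therefore far more sensitive than compound 1, compound 2 and compound 3 suggested, as each of them keeps a hydrogen on that nitrogen. Nothing available explains the loss. The compounds shown leave open whether the ring, the methyl or the missing nitrogen hydrogen matters. A dimethylamino group or an unsubstituted piperazin-1-yl group would help separate these.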